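Swapping a butyl for a phenyl on a selenocyanate carbamate

The source may hold more compounds than are shown below. What is called first, only, known or untested is meant among the compounds shown, and "the series" means these compounds.

Compound 1 `CCCCOC(=O)Nc1ccc([Se]C#N)cc1` was tested in a functional assay on PC-3 cells (Homo sapiens) for cytotoxicity, read by MTT assay, with a stated time of 72 h (on this read-out higher numbers stand for weaker inhibition of growth and lower numbers for stronger inhibition of growth), where compound 1 gives 40800 nM. Two diselenide relatives were run alongside it: compound 2 `Cc1ccc(OC(=O)Nc2ccc([Se][Se]c3ccc(NC(=O)Oc4ccc(C)cc4)cc3)cc2)cc1` gives 28200 nM in this assay, and compound 3 `O=C(Nc1ccc([Se][Se]c2ccc(NC(=O)Oc3ccc(F)cc3)cc2)cc1)Oc1ccc(F)cc1` gives 31300 nM. Compound 1 thus carries the highest of the three numbers, yet its gaps to compound 3 and to compound 2 both sit within the usual scatter of repeated measurements, so the three results cannot be told apart with confidence.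

Compound 4 `N#C[Se]c1ccc(NC(=O)Oc2ccccc2)cc1` has not yet been measured. It differs from compound 1 in one place: phenyl in place of butyl on an oxygen next to a carbonyl group. Among the measured compounds shown here, no measured pair of compounds shows the effect of this kind of swap in this assay, so there is no step to lean on. Because compound 1 gives 40800 nM and all three neighbours cluster at similar values, the step of a 1.1-fold lower number from compound 1 to compound 4 (0.05 log units; within the scatter) is expected to stay within the scatter, with no clear direction. Compound 4 is therefore estimated at 36000 nM, within a range from 12000 nM to 100000 nM.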

Compound 4, concentration for total growth inhibition: 37500 nM
Compound 4: the middle estimate sits 1.0-fold (0.02 log units) below what was measured; measured number inside the range.
By their numbers in this assay, from the lowest: compounds 2, 3, 4 and 1 (each within the scatter of the next).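

Phenyl in place of butyl on an oxygen next to a carbonyl group gives, in this assay, a 1.1-fold lower number from compound 1 to compound 4 (0.04 log units; within the scatter) and this is the first measured pair here that differs in one place. At this position, then, the butyl chain and the six-membered aromatic ring cannot be told apart by this read-out, even though the swap replaces an open chain with a ring and adds heavy atoms. Nothing available explains this result.

The compounds shown leave open whether any group on this oxygen would move the number beyond the scatter, such as a longer chain, or a chain ending in an amine or a carboxylic acid. Going by these compounds, it also remains open whether substituents on the phenyl ring of compound 4 would change the result.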